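Removing the Phenyl Group from a Spirocyclic Thiophene Core

The source may hold more compounds than are shown below. What is called first, only, known or untested is meant among the compounds shown, and "the series" means these compounds.

Of the compounds shown here, three of one series have been measured in an assay on membranes from brain for displacement of a labelled ligand from Sigma non-opioid intracellular receptor 1 (Cavia porcellus), read by scintillation counting, with a stated time of 120 min; on this read-out higher numbers stand for weaker inhibition and lower numbers for stronger inhibition. Compound 1 `COC1Cc2cc(-c3ccc(C#N)cc3)sc2C2(CCN(Cc3ccccc3)CC2)O1` gives 20 nM. For the measured compounds named here, compound 2 `COC1Cc2cc(-c3cccnc3)sc2C2(CCN(Cc3ccccc3)CC2)O1` gives 2.5 nM in this assay, and the only single-point step within the set, an 8.0-fold lower number from compound 1 to compound 2 (0.90 log units; beyond the scatter), shows that the identity of the ring on that aromatic carbon changes the number by more than the scatter. Compound 3 `COC1Cc2c(-c3ccccc3)csc2C2(CCN(Cc3ccccc3)CC2)O1`, whose phenyl sits on a different aromatic carbon of the shared core, gives 5.4 nM in this assay; on these numbers it stands second highest of the three, between compound 2 and compound 1, and both of those gaps lie beyond the scatter.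

Compound 4 `COC1Cc2ccsc2C2(CCN(Cc3ccccc3)CC2)O1` differs from compound 3 by hydrogen in place of phenyl on an aromatic carbon. Going by the values given here, no measured step removes an aromatic ring outright. Among the compounds with values here, the one recorded step, an 8.0-fold lower number from compound 1 to compound 2 (0.90 log units; beyond the scatter), exchanges one six-membered ring for another at a different place on the core, so it bears on the present change only loosely and gives no direction for a bare five-membered ring. Within the data shown here, because compound 3 gives 5.4 nM and the set contains no compound without an aryl group, a weakening beyond the scatter is expected, a 2.8-fold higher number from compound 3 to compound 4 (0.44 log units; beyond the scatter). Compound 4 is therefore estimated at 15 nM, with a range from 4 nM to 60 nM.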

Compound 4, inhibition constant: 1.9 nM
Estimate against measurement, compound 4: 7.9-fold (0.90 log units) above; measured number below the stated range.
By their numbers in this assay, from the lowest: compounds 4 and 2 (each within the scatter of the next); then compound 3; then compound 1.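

In this assay the aromatic carbon that carries the phenyl of compound 3 turns out to need no aryl group, and with hydrogen there the number falls (a 2.8-fold lower number from compound 3 to compound 4 (0.45 log units; beyond the scatter)), so on this pair the phenyl adds nothing to the inhibition and takes a little away. The same hydrogen on the aromatic carbon that holds the ring in compound 1 and compound 2 reads differently for each ring: it gives a large drop against 4-cyanophenyl (an 11-fold lower number from compound 1 to compound 4 (1.02 log units; beyond the scatter)), while against pyridin-3-yl it leaves the two compounds indistinguishable (a 1.3-fold lower number from compound 2 to compound 4 (0.12 log units; within the scatter)), which means that 4-cyanophenyl is the group that weakens inhibition at that carbon, and pyridin-3-yl is tolerated without any gain over the bare ring. Nothing measured here gives a reason for either result.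

The compounds shown leave open whether a group smaller than an aryl ring, such as a methyl group or a chlorine atom, on either aromatic carbon would keep the number near that of compound 4. They also leave open how a plain phenyl would read on the carbon that holds the pyridin-3-yl of compound 2.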